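The source may hold more compounds than are shown below. What is called first, only, known or untested is meant among the compounds shown, and "the series" means these compounds.

Measured so far:
compound 1 `Cc1cc(Nc2nccc(Nc3ccc4nc[nH]c4c3)n2)ccc1N1CCN(C)CC1`: 2.9
compound 2 `Cc1cccc(Nc2ncc([N+](=O)[O-])c(Nc3ccc4nc[nH]c4c3)n2)c1`: 3.2

In a physicochemical assay for lipophilicity, read by HPLC, using the shake flask method, measured as octanol-water partition, with a stated time of 6 h, at pH 7.4 (a lower number here means a more polar compound, a higher number a more lipophilic compound), compound 1 gives 2.9 and compound 2 gives 3.2. Compound 1 holds the lower of the two numbers, but the gap to compound 2 lies within the scatter, so the two are not separated.

Compound 3 `CN1CCN(c2ccc(Nc3nccc(Nc4ccc5nc[nH]c5c4)n3)cc2)CC1` is the next compound for this assay. It differs from compound 1 in one place: hydrogen in place of methyl on an aromatic carbon. Going by the values given here, no measured pair shows this change, so only a small downward step is expected in this assay, about a number 0.40 log units lower from compound 1 to compound 3 (beyond the scatter), near the edge of the scatter. Compound 3 is expected to give 2.5, between 2.1 and 2.9.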

Compound 3, distribution coefficient: 2.3
The estimate for compound 3 lay 0.20 log units above the measured number; measured number inside the range.
By their numbers in this assay, from the lowest: compound 3; then compounds 1 and 2 (each within the scatter of the next).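

In this assay, hydrogen in place of methyl on the aromatic carbon ortho to a 4-methylpiperazin-1-yl group gives a number 0.60 log units lower from compound 1 to compound 3 (beyond the scatter). Going by these compounds alone, this is the first one-place comparison, and it shows that this position can move the read-out, with a single carbon as the whole change. No measurement shown accounts for the size of this step.

This change rests on one pair. From the compounds shown here alone, how a chlorine, an ethyl or a methoxy group on the same carbon would compare with compound 1 and compound 3 stays open.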